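Swapping 3-nitrophenyl for 4-methoxyphenyl on a shared core

The compounds below may be only part of what the source reports. "The series", "measured", "known", "first", "only" and "open" are said of these compounds alone.

- compound 1 (`CC(C)(C)N(CCCc1ccccc1)C(=O)COC(=O)c1ccc([N+](=O)[O-])o1`) gives "not active" (no number reported)
- compound 2 (`CC(C)(C)N(CCC(=O)c1ccccc1)C(=O)COC(=O)c1ccc([N+](=O)[O-])o1`) gives "not active" (no number reported)
- compound 3 (`CC(C)(C)N(Cc1cccc([N+](=O)[O-])c1)C(=O)COC(=O)c1ccc([N+](=O)[O-])o1`) gives 78000 nM

Among the compounds with values here, in an ADME assay on HEK-293T cells (Homo sapiens) for cytotoxicity, read by MTT assay, with a stated time of 3 days (on this read-out lower numbers stand for higher toxicity in this test and higher numbers for lower toxicity in this test), compound 3 gives 78000 nM as the only number, so compound 1 and compound 2 offer no number to rank it against. The unmeasured compound 4 (`COc1ccc(CN(C(=O)COC(=O)c2ccc([N+](=O)[O-])o2)C(C)(C)C)cc1`) differs from compound 3 at one place: 4-methoxyphenyl in place of 3-nitrophenyl on a saturated chain carbon bound to an amide-type nitrogen. Within the data shown here, no measured step exists to guide this change, so no shift beyond the usual scatter is expected in this assay in either direction. The estimated step of a 1.0-fold higher number from compound 3 to compound 4 (0.01 log units; within the scatter) is therefore small. For compound 4 the estimated value is 80000 nM (expected range 30000 nM to 200000 nM).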

Compound 4, half-maximal cytotoxic concentration: > 100000 nM
Compound 4: no number, only a limit; the forecaster's own chance of this, stated with the estimate: 40%; middle value at least 1.2-fold (0.09 log units) from the limit.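

In this assay compound 4 gives > 100000 nM, which is a limit of the assay and not a number. Within the data shown here, putting 4-methoxyphenyl in place of 3-nitrophenyl on a saturated chain carbon bound to an amide-type nitrogen gives an at least 1.2-fold higher number from compound 3 to compound 4 (0.10 log units; that floor lies within the scatter), the first step that can be read at this position. Its true size stays unknown because one value is only a limit: the limit of > 100000 nM in this assay, at which 1 of the 4 values shown sits.

From the compounds shown here alone, whether the change reaches beyond the usual scatter stays open. So does the effect of an amine or a carboxylic acid in place of the methoxy group at this position.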